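This account rests on a few compounds, and the source may have more. Where it says the series, first, only, none or still open, it means among the compounds named here.

Measured in a physicochemical assay, read by spectrophotometry, with a stated time of 6 min; on this read-out higher numbers stand for weaker inhibition and lower numbers for stronger inhibition:
- compound 1 `O=C(CCc1nc2ccccc2c(=O)[nH]1)N/N=C/c1ccc([N+](=O)[O-])cc1`: 220000000 nM
- compound 2 `COc1ccc(/C=N/NC(=O)CCCc2nc3ccccc3c(=O)[nH]2)cc1`: 180000000 nM
- compound 3 `COc1cc(/C=N/NC(=O)CCc2nc3ccccc3c(=O)[nH]2)cc(OC)c1O`: 105000000 nM

Compound 1 sits at the weak end of this small set, level with compound 2 within the scatter, while compound 3 shows a lower number than compound 1, just beyond the scatter.

Compound 4 `O=C(CCc1nc2ccccc2c(=O)[nH]1)N/N=C/c1cc(O)c(O)c(O)c1` keeps the core of compound 1 and changes one group: 3,4,5-trihydroxyphenyl in place of 4-nitrophenyl on a carbon with a double bond to nitrogen. Among the compounds with values here, no measured pair isolates this change. The closest guide is compound 3, whose aromatic ring also carries a hydroxy group and which gives 105000000 nM, so a moderate move towards stronger inhibition is expected. The expected change is a 5.5-fold lower number from compound 1 to compound 4 (0.74 log units; beyond the scatter). For compound 4 the estimated value is 40000000 nM, with an expected range of 12000000 nM to 120000000 nM.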

Compound 4, half-maximal inhibitory concentration: 35000000 nM
The estimate for compound 4 lay 1.1-fold (0.06 log units) above the measured number; the range from low to high includes it.
By their numbers in this assay, from the lowest: compound 4; then compounds 3, 2 and 1 (each within the scatter of the next, the first and the last beyond it).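

Within the data shown here, this is the first pair in the set that differs in one place only, so the group on the carbon with a double bond to nitrogen can be read directly. In this assay, 3,4,5-trihydroxyphenyl in place of 4-nitrophenyl gives a 6.3-fold lower number from compound 1 to compound 4 (0.80 log units; beyond the scatter), so with the core unchanged, this position does respond to the group it carries. No measurement here gives a reason for this step.

On these data alone, whether the step comes from gaining the hydroxy groups or losing the nitro group stays open. As far as these compounds go, how a phenyl ring carrying an amine or a carboxylic acid would read here also remains open.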